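Methoxy for Methyl: Carrying One Step onto a Second Core

A few compounds are considered here, and "the series" means these few. Any claim that something is new, unique, unknown or untested is made for them only; others in the source may bear on it.

Measured so far, in an assay on cells for inhibition of Amine oxidase [flavin-containing] B (Homo sapiens), read by fluorescence and Amplex Red, with a stated time of 15 min; on this read-out higher numbers stand for weaker inhibition and lower numbers for stronger inhibition:
compound 1 `Cc1ccc2oc(=O)c(-c3ccc(Br)nn3)cc2c1` gives 2160 nM
compound 2 `COc1ccc2oc(=O)c(-c3ccc(Br)nn3)cc2c1` gives 560 nM
compound 3 `Cc1cccc2cc(-c3ccc(Cl)nn3)c(=O)oc12` gives 22700 nM

Compounds 1 and 2 share a core and differ only by methoxy in place of methyl on an aromatic carbon; this change made the step of a 3.9-fold lower number from compound 1 to compound 2 (0.59 log units; beyond the scatter). Compound 3 has a different core, and how its core differs from that of compound 1 is not broken down here. Compound 4 `COc1cccc2cc(-c3ccc(Cl)nn3)c(=O)oc12` has not been measured; it differs from compound 3 by methoxy in place of methyl on an aromatic carbon. Going by the values given here, the change is the same kind as the one from compound 1 to compound 2, but the place is not the same: in compound 4 the new group sits ortho to a fused ring and meta to a fused ring, whereas in compound 2 it sits meta to a fused ring and para to a fused ring. Among the compounds with values here, for compound 4 in this assay a step of a 2.8-fold lower number from compound 3 to compound 4 (0.45 log units; beyond the scatter) is expected, resting on the only example, the step of a 3.9-fold lower number from compound 1 to compound 2 (0.59 log units; beyond the scatter). The place differs, and the range is set wide. The estimate for compound 4 is 8000 nM, expected between 3000 nM and 25000 nM.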

Compound 4, half-maximal inhibitory concentration: 30100 nM
Compound 4: the middle estimate sits 3.8-fold (0.58 log units) below what was measured; the measured number lies above the stated range.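

In this assay, methoxy in place of methyl on the second core gave a 1.3-fold higher number from compound 3 to compound 4 (0.12 log units; within the scatter), a step too small to tell apart from ordinary repeat variation. The clear drop seen on the first core therefore did not carry over, and the two steps truly differ: the same change on two cores in this assay, a 3.9-fold lower number (0.59 log units; beyond the scatter) from compound 1 to compound 2 and a 1.3-fold higher number (0.12 log units; within the scatter) from compound 3 to compound 4, 5.1-fold (0.71 log units) apart, beyond the scatter of two such steps. This does not show what sets them apart, as the two pairs differ both in core and in where the group sits, and these data cannot separate those two factors.

Still open, from the compounds shown here alone, is what methoxy would do on the core of compound 3 at the place it holds in compound 2. Also open, going by these compounds, is how either core would respond to a different group there, such as an amine or a longer chain like ethoxy.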